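Pyrrolidinyl for dimethylamino on the bridged aminoketone cores

The source may report more compounds than this note shows. Statements on the series, on what has been measured and on what is new or still open speak of the compounds shown alone.

The series in hand is built on a bridged bicyclic core carrying a tertiary amine on a saturated ring carbon and two para-substituted phenyl rings. Compound 1 `COc1ccc(C2CC3(N(C)C)CC(=O)C2C(c2ccc(OC)cc2)C3)cc1` is the dimethylamino member with two 4-methoxyphenyl groups and a ketone; in an ADME assay on L6 cells (Rattus norvegicus) for cytotoxicity (on this read-out lower numbers stand for stronger inhibition and higher numbers for weaker inhibition), compound 1 gives 52400 nM. Compound 2 `COc1ccc(C2CC3(N4CCCC4)CC(=O)C2C(c2ccc(OC)cc2)C3)cc1` carries the change (pyrrolidin-1-yl in place of dimethylamino on a saturated ring carbon); in this assay compound 2 gives 41900 nM, so that a 1.3-fold lower number from compound 1 to compound 2 (0.10 log units; within the scatter).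

Compound 3 `CN(C)C12CC(O)C(C(c3ccc(Cl)cc3)C1)C(c1ccc(Cl)cc1)C2` keeps the dimethylamino group but has two 4-chlorophenyl groups and a hydroxy group in place of the ketone; the difference between its core and the core of compound 1 is not broken down here. In this assay compound 3 gives 8770 nM, the lowest of the three numbers measured, and its steps to compound 2 and to compound 1 both lie beyond the scatter.

Compound 4 `OC1CC2(N3CCCC3)CC(c3ccc(Cl)cc3)C1C(c1ccc(Cl)cc1)C2` stands to compound 3 as compound 2 stands to compound 1, through (pyrrolidin-1-yl in place of dimethylamino on a saturated ring carbon). The surroundings differ: here the ring atom two bonds away bears a 4-chlorophenyl group rather than a 4-methoxyphenyl group, and a further ring atom bears a hydroxy group, so this is the same kind of change rather than the same change. Among the compounds with values here, the only measured instance of this change is a 1.3-fold lower number from compound 1 to compound 2 (0.10 log units; within the scatter). On that basis a step of the same size is expected: a 1.3-fold lower number from compound 3 to compound 4 (0.11 log units; within the scatter). Compound 4 is therefore estimated at 6800 nM in this assay, with a likely range from 3000 nM to 15000 nM.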

Compound 4, half-maximal inhibitory concentration: 3590 nM
Compound 4: the middle estimate sits 1.9-fold (0.28 log units) above what was measured, within the range that was stated.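

In this assay, pyrrolidin-1-yl in place of dimethylamino on the core of compound 3 gives a 2.4-fold lower number from compound 3 to compound 4 (0.39 log units; beyond the scatter), a modest step. Set beside the step on the core of compound 1, this gives no sign that the size of the step depends on the core: the same change on two cores in this assay, a 1.3-fold lower number (0.10 log units; within the scatter) from compound 1 to compound 2 and a 2.4-fold lower number (0.39 log units; beyond the scatter) from compound 3 to compound 4, 2.0-fold (0.29 log units) apart, within the scatter of two such steps This supports carrying the change between these two cores with a similar expected step, but it rests on only two pairs, only one of which lies beyond the scatter, and so it does not show that the change lowers the number on every core in the series or give a firm size for the step.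

The compounds shown leave open whether other cyclic amines on the same saturated ring carbon, such as piperidin-1-yl or morpholin-4-yl, would follow pyrrolidin-1-yl, and whether an acyclic amine such as diethylamino would sit with dimethylamino or with pyrrolidin-1-yl. They also leave open how the 4-chlorophenyl groups and the hydroxy group each bear on the read-out, which a core carrying only one of these features would separate.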